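A few compounds are considered here, and "the series" means these few. Any claim that something is new, unique, unknown or untested is made for them only; others in the source may bear on it.

Two chalcones have been measured for cytotoxicity in a functional assay on DLD-1 cells (Homo sapiens) for cytotoxicity, read by resazurin assay, with a stated time of 48 h; on this read-out higher numbers stand for an effect only at larger amounts of compound and lower numbers for an effect already at smaller amounts. Compound 1 `O=C(/C=C/c1ccc([N+](=O)[O-])cc1)c1ccc(O)c(O)c1` gives 9600 nM in this assay. Compound 2 `CC(=O)Nc1ccc(C(=O)/C=C/c2cccc([N+](=O)[O-])c2)cc1` gives 6300 nM in this assay, which is the lower of the two numbers; compound 1 is the nearest, and the gap between them lies within the scatter of repeated measurements, so the two cannot be ordered.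

Compound 3 `O=C(/C=C/c1cccc([N+](=O)[O-])c1)c1ccc(NC(=O)c2ccco2)cc1` is the next compound, not yet measured. It differs from compound 2 by one change: furan-2-yl in place of methyl on a carbonyl carbon. Within the data shown here, no pair of measured compounds differs in a single place, so there is no measured step to lean on. A modest lowering of the number in this assay is expected, roughly at the edge of the scatter, the step of a 1.6-fold lower number from compound 2 to compound 3 (0.20 log units; within the scatter) being the expected size. Compound 3 is therefore estimated at 4000 nM in this assay, within a range from 1500 nM to 12000 nM.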

Compound 3, half-maximal effective concentration: 22000 nM
Compound 3: middle estimate off by 5.5-fold (0.74 log units), on the low side, and the stated range ends below it.
By their numbers in this assay, from the lowest: compounds 2 and 1 (each within the scatter of the next); then compound 3.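

In this assay, among these compounds, the change made on a carbonyl carbon whose other neighbour is an amide-type nitrogen gives a 3.5-fold higher number from compound 2 to compound 3 (0.54 log units; beyond the scatter), the only measured step here and one that lies beyond the scatter. At this position, going from acetamido to ((furan-2-yl)carbonyl)amino therefore moves the compound towards needing larger amounts for the effect, so the position is not indifferent to this change. No measurement given here offers an explanation for this shift.

How a phenyl ring or a longer chain such as propyl would read on the same carbonyl carbon stays open, so the compounds shown cannot separate the effect of the ring oxygen from that of the ring itself. On these data alone, whether the same change would give a step of similar size on the core of compound 1 is also open.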